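A few compounds are considered here, and "the series" means these few. Any claim that something is new, unique, unknown or untested is made for them only; others in the source may bear on it.

Of the compounds shown here, two sharing one core have been measured so far in a functional assay on HCT-116 cells (Homo sapiens) for inhibition, read by CCK-8 assay, with a stated time of 72 h, tested at 8 uM; a lower number here means less inhibition of growth, a higher number more inhibition of growth at the concentration tested. Compound 1 `COc1ccc(SCc2ccc(/C=C/C(=O)Nc3ccccc3N)cc2)cc1OC`, with 3,4-dimethoxyphenyl on a sulfur, gives 49.5%. Compound 2 `Nc1ccccc1NC(=O)/C=C/c1ccc(CSc2ccc(C(F)(F)F)cn2)cc1`, with 5-(trifluoromethyl)pyridin-2-yl on that sulfur, gives 14.9%, the lower of the two numbers. Compound 3 `Nc1ccccc1NC(=O)/C=C/c1ccc(CSCCc2ccccc2)cc1` keeps the core and changes the same place, with phenethyl in place of 5-(trifluoromethyl)pyridin-2-yl on a sulfur. Within the data shown here, only one measured step bears on this change, a number 34.6 percentage points lower from compound 1 to compound 2 (beyond the scatter), which is large and beyond the scatter. It shows that, in this pair, exchanging the group on the sulfur goes with a big shift in the number. Neither measured compound carries phenethyl, so that step is only a rough guide. Phenethyl does bring a six-membered aromatic ring of carbon only, as does the group on compound 1 at 49.5%, so a rise of moderate size is expected, smaller than the measured step and opposite in direction. The expected change is estimated as a number 20.1 percentage points higher from compound 2 to compound 3 (beyond the scatter). For compound 3 the estimated value is 35%, with an expected range of 14% to 58%.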

Compound 3, percent growth inhibition at one concentration: 10.6%
For compound 3 the middle estimate is 24.4 percentage points above the measured one; the whole stated range lies above it.
By their numbers in this assay, from the lowest: compounds 3 and 2 (each within the scatter of the next); then compound 1.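

In this assay, a six-membered aromatic ring of carbon only does not by itself go with the higher number: phenethyl carries such a ring, as 3,4-dimethoxyphenyl does, yet exchanging one for the other on the sulfur gives a number 38.9 percentage points lower from compound 1 to compound 3 (beyond the scatter), a large step. Exchanging 5-(trifluoromethyl)pyridin-2-yl for phenethyl gives a number 4.3 percentage points lower from compound 2 to compound 3 (within the scatter), so two groups that differ in ring type and in their atoms leave the number in the same range, and of the three compounds only compound 1 stands apart. No measurement at hand ties these numbers to a cause.

The compounds shown leave open which part of 3,4-dimethoxyphenyl goes with the higher number, as a plain phenyl or a phenyl with a single methoxy group on the sulfur would be needed to separate the ring from its two methoxy groups. They also leave open how the number responds to an amine or a carboxylic acid on that ring, or to a longer chain between the sulfur and the ring.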